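A few compounds are considered here, and "the series" means these few. Any claim that something is new, unique, unknown or untested is made for them only; others in the source may bear on it.

Of the compounds shown here, three have so far been measured in a functional assay (blood) for inhibition, with Homo sapiens as the target; a lower number here means a stronger inhibitor, a higher number a weaker inhibitor. Compound 1 `C/C(=N\OCCSc1nnc(C)s1)c1ccc(Sc2cc(F)cc(C3CCOCC3)c2)cc1` gives 230 nM in this assay. Compound 2 `C/C(=N\O)c1cccc(Sc2cc(F)cc(C3CCOCC3)c2)c1` gives 2910 nM in this assay, and compound 3 `CO[C@]1(c2cc(F)cc(Sc3ccc(/C(C)=N/OCC#N)cc3)c2)CCO[C@@H](C)C1` gives 40 nM. Among these three numbers compound 1 stands second highest: compound 3 lies at a lower number than compound 1, while compound 2 lies at a higher one, and both of these gaps fall beyond the usual scatter of repeated measurements.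

Compound 4 `COC(=O)C(C)(C)CO/N=C(\C)c1ccc(Sc2cc(F)cc(C3CCOCC3)c2)cc1` has not yet been measured. It differs from compound 1 in one place: 1-(methoxycarbonyl)-1-methylethyl in place of ((5-methyl-1,3,4-thiadiazol-2-yl)sulfanyl)methyl on a saturated chain carbon bound to an oxygen. Among the compounds with values here, no pair of measured compounds isolates this kind of exchange, so nothing in the measured set speaks directly to its size or direction. The three measured values do show that compounds built on the shared core spread over a wide range in this assay, and the exchange in compound 4 alters only the group carried on the saturated chain carbon bound to an oxygen while leaving the rest of compound 1 intact. The step of a 1.3-fold higher number from compound 1 to compound 4 (0.12 log units; within the scatter) is therefore expected to be modest, with no strong lean in either direction. Compound 4 is accordingly expected to give about 300 nM in this assay, within a range from 80 nM to 1100 nM.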

Compound 4, half-maximal inhibitory concentration: 420 nM
Compound 4: the middle estimate sits 1.4-fold (0.15 log units) below what was measured; measured number inside the range.
By their numbers in this assay, from the lowest: compound 3; then compounds 1 and 4 (each within the scatter of the next); then compound 2.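

In this assay, within the data shown here, exchanging ((5-methyl-1,3,4-thiadiazol-2-yl)sulfanyl)methyl for 1-(methoxycarbonyl)-1-methylethyl on a saturated chain carbon bound to an oxygen gives a 1.8-fold higher number from compound 1 to compound 4 (0.26 log units; within the scatter), the first comparison in this set in which only one place differs. At this position, then, the five-membered aromatic ring with 3 hetero atoms can give way to a group with no ring and a different count of hydrogen-bond acceptors without a change that can be told from the scatter, although this rests on a single pair and holds only for these two groups. No measurement is available that bears on why these two compounds read alike.

From the compounds shown here alone, what remains open is whether the methyl ester of the entering group matters at all, since a carboxylic acid, a primary amide or a plain tert-butyl group in the same place would separate the ester from the branched carbon chain that carries it. Going by these compounds, it is also open whether an amine such as morpholine or a longer chain at this position would keep the number in the same range.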